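A Second Methoxy on the Aryl Ring of Compound 2

This account rests on a few compounds, and the source may have more. Where it says the series, first, only, none or still open, it means among the compounds named here.

Compound 2 `CCOC(=O)C12C(=O)OCC=C1COC2c1ccc(OC)cc1` and compound 1 `CCOC(=O)C12C(=O)OCC=C1COC2c1ccc(F)cc1` share one core and differ only in the group carried on the aromatic ring. In a functional assay on A549 cells (Homo sapiens) for cytotoxicity, read by MTT assay (on this read-out lower numbers stand for stronger inhibition and higher numbers for weaker inhibition), compound 1 gives > 1000000 nM, which is a limit of the assay rather than a number. In this assay, among the measured compounds shown here, compound 2 gives 9300 nM, the only outright number among the measured values. The step of an at least 100-fold lower number from compound 1 to compound 2 (2.03 log units; beyond the scatter) is bounded by the limit of > 1000000 nM in this assay, at which 1 of the 2 values shown sits. Compound 3 `CCOC(=O)C12C(=O)OCC=C1COC2c1ccc(OC)c(OC)c1` differs from compound 2 by methoxy in place of hydrogen on an aromatic carbon. For the measured compounds named here, only one measured step exists, and it concerns a different exchange, fluoro for methoxy, so it gives no direct guide for adding a second methoxy. Only a modest move is therefore expected, most likely toward a lower number, with the step of a 1.6-fold lower number from compound 2 to compound 3 (0.19 log units; within the scatter). Compound 3 is estimated at 6000 nM, with a range from 1500 nM to 25000 nM.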

Compound 3, half-maximal inhibitory concentration: > 1000000 nM
Compound 3: a limit, no number; the forecaster's own chance of this, stated with the estimate: 10%; middle value at least 160-fold (2.22 log units) away from the limit.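

Putting a second methoxy on the aromatic ring, ortho to the methoxy group already there and meta to a large group, is far from a small change in this assay: the result is an at least 100-fold higher number from compound 2 to compound 3 (2.03 log units; beyond the scatter). In this assay compound 3 gives > 1000000 nM, which is a limit and not a number. Compound 2 therefore remains the only compound with an outright number, and both single changes from it, fluoro in place of methoxy and this added methoxy, lead to the same limit: the limit of > 1000000 nM in this assay, at which 2 of the 3 values shown sit.

The compounds shown leave open whether a hydroxyl, an amine or a chlorine on this same ring carbon would keep a measurable value. They also leave open whether a second methoxy on a different carbon of the ring would give a number.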